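Swapping bromo for trifluoromethyl on the thiazole-linked ring

This account rests on a few compounds, and the source may have more. Where it says the series, first, only, none or still open, it means among the compounds named here.

Of the compounds shown here, three built on one shared core have been tested in a functional assay on WM 266-4 cells (Homo sapiens) for antiproliferative activity, read by MTT assay, with a stated time of 48 h; on this read-out lower numbers stand for stronger inhibition and higher numbers for weaker inhibition. Compound 1 `COc1ccc(C2=NN(c3nc(-c4ccc(C(F)(F)F)cc4)cs3)C(c3cccs3)C2)cc1` gives 8110 nM. Compound 2 `FC(F)(F)c1ccc(-c2csc(N3N=C(c4ccc(Br)cc4)CC3c3cccs3)n2)cc1` gives 27400 nM. Compound 3 `Clc1ccc(C2=NN(c3nc(-c4ccc(Br)cc4)cs3)C(c3cccs3)C2)cc1` gives 1450 nM, the lowest of the three numbers and therefore the strongest inhibitor among them; the gap to compound 1 is beyond the scatter, and the gap to compound 2 is larger still. Within the data shown here, the one step measured between single-point changes, a 3.4-fold higher number from compound 1 to compound 2 (0.53 log units; beyond the scatter), concerns a different ring than the one altered here.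

Compound 4 `FC(F)(F)c1ccc(-c2csc(N3N=C(c4ccc(Cl)cc4)CC3c3cccs3)n2)cc1` is derived from compound 3 by the change (trifluoromethyl in place of bromo on an aromatic carbon), on an aromatic carbon of a six-membered aromatic ring of carbon only, para to a large group. Among the measured compounds shown here, no measured pair differs only in this way, so the single step on record gives no direct guidance, and compounds 2 and 3, which carry the two groups in question, also differ elsewhere. Without a comparable step, the expectation for a 1.7-fold higher number from compound 3 to compound 4 (0.24 log units; within the scatter) is a change of uncertain direction, most likely staying within or near the scatter. Compound 4 is therefore estimated at 2500 nM, with a range from 800 nM to 8000 nM.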

Compound 4, half-maximal inhibitory concentration: 120 nM
Estimate against measurement, compound 4: 21-fold (1.32 log units) above; measured number below the stated range.
By their numbers in this assay, from the lowest: compound 4; then compound 3; then compound 1; then compound 2.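

In this assay, going from 4-bromophenyl to 4-(trifluoromethyl)phenyl is a large step (a 12-fold lower number from compound 3 to compound 4 (1.08 log units; beyond the scatter)), so this aromatic carbon is far from indifferent to the group it carries. Compound 4 also shows that the trifluoromethyl group can go with a much lower number than compounds 1 and 2 alone suggested, as long as the other aromatic ring carries chloro: chloro in place of bromo gives a 230-fold lower number from compound 2 to compound 4 (2.36 log units; beyond the scatter), and chloro in place of methoxy gives a 68-fold lower number from compound 1 to compound 4 (1.83 log units; beyond the scatter). With every step to it beyond the scatter, compound 4 is the strongest inhibitor of the four, and the single-place steps show that the result depends heavily on the groups at both places.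

Still open, going by these compounds, is whether a nitrile, an amine or a carboxylic acid on this aromatic carbon would lower the number further, and whether trifluoromethyl gives a step of this size when the other ring carries something other than chloro. Nothing available here explains why these changes have such large effects.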